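The compounds below may be only part of what the source reports. "The series", "measured", "known", "first", "only" and "open" are said of these compounds alone.

In a functional assay on G-361 cells (Homo sapiens) for inhibition, with a stated time of 72 h (on this read-out higher numbers stand for weaker inhibition and lower numbers for stronger inhibition), compound 1 (`NC1CCC(Nc2nc(NCc3ccc(-c4ccccc4)cc3)c3ncn(C4CCCC4)c3n2)CC1`) gives 1020 nM as the highest of the three measured numbers. Compound 2 (`NC1CCC(Nc2nc(NCc3ccc(-c4cccs4)nc3)c3ncn(C4CCCC4)c3n2)CC1`) gives 150 nM and compound 3 (`NC1CCC(Nc2nc(NCc3ccc(-c4ccsc4)nc3)c3ncn(C4CCCC4)c3n2)CC1`) gives 272 nM in the same read-out. Compound 4 (`NC1CCC(Nc2nc(NCc3ccc(-c4ccccc4O)cc3)c3ncn(C4CCCC4)c3n2)CC1`) differs from compound 1 in one place (hydroxy in place of hydrogen on an aromatic carbon), with hydroxy in place of hydrogen on an aromatic carbon. The measured steps bear on this only indirectly. Replacing the whole 4-phenylphenyl group gives a 6.8-fold lower number from compound 1 to compound 2 (0.83 log units; beyond the scatter) and a 3.8-fold lower number from compound 1 to compound 3 (0.57 log units; beyond the scatter) while exchanging thiophen-2-yl for thiophen-3-yl gives a 1.8-fold higher number from compound 2 to compound 3 (0.26 log units; within the scatter) and none of them adds a hydroxy. In this assay only a slight lowering is therefore expected, with no step beyond the scatter. The expected step is a 1.5-fold lower number from compound 1 to compound 4 (0.16 log units; within the scatter) and remains tentative. For compound 4 the estimated value is 700 nM (expected range 250 nM to 2000 nM).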

Compound 4, half-maximal inhibitory concentration: 4150 nM
Compound 4: the middle estimate sits 5.9-fold (0.77 log units) below what was measured, and the stated range ends below it.
By their numbers in this assay, from the lowest: compounds 2 and 3 (each within the scatter of the next); then compound 1; then compound 4.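

In this assay, the change from phenyl to 2-hydroxyphenyl, which places hydroxy ortho to a large group, gives a 4.1-fold higher number from compound 1 to compound 4 (0.61 log units; beyond the scatter) and so moves the number upward. The earlier steps shown here from compound 1 replaced the whole 4-phenylphenyl group and lowered the number, so compound 4 shows that one added hydroxy on the outer ring can act in the opposite direction. No available evidence accounts for this rise. The compounds shown leave open whether methoxy, an amine or fluorine at this same place would also raise the number. They also leave open whether hydroxy on another carbon of that ring would do so.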